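Replacing a chlorinated aryl by a ketone on the sulfur arm

The compounds below may be only part of what the source reports. "The series", "measured", "known", "first", "only" and "open" are said of these compounds alone.

Three compounds share one core and differ only in the group carried on the saturated chain carbon bound to a sulfur. Compound 1 `C=CCSc1nnc(CCC)n1N1C(=O)c2ccccc2C1=O` carries a vinyl group there, compound 2 `C#CCSc1nnc(CCC)n1N1C(=O)c2ccccc2C1=O` an ethynyl group, and compound 3 `CCCc1nnc(SCc2ccccc2Cl)n1N1C(=O)c2ccccc2C1=O` a 2-chlorophenyl group. In a functional assay on PC-3M cells (Homo sapiens) for cytotoxicity, read by MTT assay, with a stated time of 48 h (a higher number here means a weaker inhibitor, a lower number a stronger inhibitor), compound 1 gives only a limit of the assay, > 200000 nM. In this assay compound 2 likewise gives a limit, > 200000 nM. For compound 3 this assay also reports a limit, > 200000 nM. Compound 3 therefore stands nowhere in particular among the measured numbers: all three sit at the same limit, as summed up by the limit of > 200000 nM in this assay, at which 3 of the 3 values shown sit. The steps a step that the two limits leave unreadable from compound 1 to compound 2, a step that the two limits leave unreadable from compound 1 to compound 3 and a step that the two limits leave unreadable from compound 2 to compound 3 are accordingly unreadable in size, and none of them shows whether changing the group on this carbon moves the number at all.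

Compound 4 `CCCc1nnc(SCC(=O)c2ccccc2)n1N1C(=O)c2ccccc2C1=O` is not yet measured. It differs from compound 3 by benzoyl in place of 2-chlorophenyl on a saturated chain carbon bound to a sulfur. Since the measured steps give no readable size, the expectation for compound 4 rests on the shared limit of compounds 1, 2 and 3, and compound 4 is estimated to remain near that limit, with a step that the limit leaves unreadable from compound 3 to compound 4 that is expected to be within the scatter. Compound 4 is expected to give about 300000 nM in this assay, within the range 100000 nM to 1000000 nM.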

Compound 4, half-maximal inhibitory concentration: > 200000 nM
Compound 4 ended at the assay's limit; the forecaster's own chance of this, stated with the estimate: 80%; the middle value lies beyond the limit too.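

In this assay, going by these compounds alone, compound 4 also gives only a limit, so its steps from compound 1, compound 2 and compound 3 cannot be read, and no new step emerges. All four compounds now share one result: the limit of > 200000 nM in this assay, at which 4 of the 4 values shown sit. The compounds shown leave open whether any group on this carbon moves the number at all.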